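The source may report more compounds than this note shows. Statements on the series, on what has been measured and on what is new or still open speak of the compounds shown alone.

Of the compounds shown here, three with the same shared core have been measured in an ADME assay on THP-1 cells (Homo sapiens) for cytotoxicity; on this read-out lower numbers stand for stronger inhibition and higher numbers for weaker inhibition. Compound 1, `COc1ccccc1-c1nnc(-c2ccc(C(=O)N/N=C/c3cccc(F)c3)cc2)o1`, gives 353000 nM. Compound 2, `COc1ccccc1-c1nnc(-c2ccc(C(=O)N/N=C/c3cccc([N+](=O)[O-])c3)cc2)o1`, gives 119000 nM, and compound 3, `COc1ccccc1-c1nnc(-c2ccc(C(=O)N/N=C/c3ccccc3[N+](=O)[O-])cc2)o1`, gives 161000 nM. Compound 2 stands at the lowest of the three numbers, but its nearest neighbour, compound 3, lies within the scatter, so the two cannot be ranked; only compound 1 is clearly set apart, a 3.0-fold lower number from compound 1 to compound 2 (0.47 log units; beyond the scatter).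

The new compound 4, `COc1ccccc1-c1nnc(-c2ccc(C(=O)N/N=C/c3ccccc3O)cc2)o1`, changes compound 2 in one place: 2-hydroxyphenyl in place of 3-nitrophenyl on a carbon with a double bond to nitrogen. Within the data shown here, two measured steps bear on this. Going from fluoro to nitro on the ring gave a 3.0-fold lower number from compound 1 to compound 2 (0.47 log units; beyond the scatter), a step beyond the scatter, and moving the nitro group to another position gave a 1.4-fold higher number from compound 2 to compound 3 (0.13 log units; within the scatter), which is within the scatter. Removing the nitro group, as happens here, therefore points back toward higher numbers, while the incoming hydroxyphenyl has no measured precedent among these compounds, so the size is uncertain. A modest rise is expected, a 1.9-fold higher number from compound 2 to compound 4 (0.29 log units; within the scatter), in this assay. The estimate for compound 4 in this assay is 230000 nM, with a likely range from 100000 nM to 500000 nM.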

Compound 4, half-maximal inhibitory concentration: 207000 nM
Compound 4: the middle estimate sits 1.1-fold (0.05 log units) above what was measured; measured number inside the range.
By their numbers in this assay, from the lowest: compounds 2, 3, 4 and 1 (each within the scatter of the next, the first and the last beyond it).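

Replacing the nitro-bearing ring at this position with a hydroxy-bearing one has no effect that can be told from scatter in this assay: the change gives a 1.7-fold higher number from compound 2 to compound 4 (0.24 log units; within the scatter) and, with the group swapped directly on the ring, hydroxy in place of nitro gives a 1.3-fold higher number from compound 3 to compound 4 (0.11 log units; within the scatter), so a nitro group is not needed for a number in this range. The comparison with the fluoro compound is less clear-cut, since 2-hydroxyphenyl in place of 3-fluorophenyl gives a 1.7-fold lower number from compound 1 to compound 4 (0.23 log units; within the scatter) and that step also stays within the scatter, whereas both nitro compounds lie beyond it from compound 1, which leaves compound 4 inseparable from either end of the series. Nothing measured here explains these small differences.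

As far as these compounds go, whether a ring carrying an amine or a carboxylic acid at this same place would give a number clearly apart from these four remains open. So does the plain phenyl ring with no added group, which would show what each of the groups seen so far contributes on its own.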